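The source may report more compounds than this note shows. Statements on the series, on what has been measured and on what is new or still open speak of the compounds shown alone.

In a functional assay on HL-60 cells (Homo sapiens) for inhibition, read by MTT assay, with a stated time of 72 h (on this read-out lower numbers stand for stronger inhibition and higher numbers for weaker inhibition), two compounds of the same series have been measured. Compound 1, `CCc1nc(-c2ccccc2F)c(C(=O)N2CCN(c3cccc(Cl)c3)CC2)o1`, is the reference point: in this assay compound 1 gives 139 nM. Compound 2, `C=C(C)c1ccc(N2CCN(C(=O)c3oc(C)nc3-c3ccccc3)CC2)cc1`, shares the amide-linked core and the six-membered non-aromatic ring with two nitrogens, but differs elsewhere, and in this assay compound 2 is reported as "not active" (no number reported); no number stands beside it, so it offers no measured scale, only the statement that inhibition was not seen.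

Compound 3, `Cc1nc(-c2ccccc2)c(C(=O)N2CCN(c3ccc(C)c(C)c3)CC2)o1`, is the next compound to be tested, and it is built from compound 2 by a single exchange on the amine nitrogen in a ring: 3,4-dimethylphenyl in place of 4-(1-methylethenyl)phenyl on an amine nitrogen in a ring. The outgoing group carries one double bond outside aromatic rings, the incoming 3,4-dimethylphenyl carries none; neither has hydrogen-bond donors or acceptors, and both are without net charge.

Within the data shown here, with no numbered step between measured compounds, no size of step in this assay can be inferred. Since compound 2 gives "not active" (no number reported), compound 3 is expected to remain weak, estimated at 15000 nM with a range from 2000 nM to 100000 nM.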

Compound 3, half-maximal inhibitory concentration: 43 nM
Beside the measured number, compound 3's estimate is 350-fold (2.54 log units) above it; the whole stated range lies above it.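

In this assay, among these compounds, compound 2 has no number, so no step to compound 3 can be read, although compound 3 gives 43 nM. The compounds shown leave open how large the effect of exchanging 4-(1-methylethenyl)phenyl for 3,4-dimethylphenyl is. Nothing shown offers an explanation for the result.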